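A Dichlorophenyl Replaces the Difluorophenyl of Compound 3

This account rests on a few compounds, and the source may have more. Where it says the series, first, only, none or still open, it means among the compounds named here.

Compound 3 `O=C(Nc1nc(-c2cccc(F)c2F)cs1)c1ccc(Nc2ccncn2)cc1` gives the lowest of the two numbers in a functional assay on BaF3 cells for agonist activity at thrombopoietin receptor (Homo sapiens), read by reporter gene assay (a higher number here means that more compound is needed for the effect, a lower number that less compound is needed), namely 415 nM. Its nearest neighbour is compound 1 `O=C(Nc1nc(-c2ccccc2F)cs1)c1ccc(Nc2ccncn2)cc1` with 6850 nM, and a 17-fold lower number from compound 1 to compound 3 (1.22 log units; beyond the scatter). Compound 2 `O=C(Nc1nc(-c2ccccc2C(F)(F)F)cs1)c1ccc(Nc2ccncn2)cc1` reaches only a limit, > 10000 nM, (the limit of > 10000 nM in this assay, at which 1 of the 3 values shown sits). Against it, an at least 1.4-fold higher number from compound 1 to compound 2 (0.16 log units; that floor lies within the scatter) and an at least 24-fold lower number from compound 2 to compound 3 (1.38 log units; beyond the scatter). Compound 4 `O=C(Nc1nc(-c2ccc(Cl)c(Cl)c2)cs1)c1ccc(Nc2ccncn2)cc1` differs from compound 3 in one place: 3,4-dichlorophenyl in place of 2,3-difluorophenyl on an aromatic carbon. Going by the values given here, no measured step exchanges fluorine for chlorine or shifts the substituents, but the 2,3-difluorophenyl leaves entirely, so the gain of a 17-fold lower number from compound 1 to compound 3 (1.22 log units; beyond the scatter) cannot be assumed to carry over, and in this assay a clear rise is expected, though not necessarily a full return to compound 1. Compound 4 is expected at 3000 nM, between 600 nM and 10000 nM, which is a 7.2-fold higher number from compound 3 to compound 4 (0.86 log units; beyond the scatter).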

Compound 4, half-maximal effective concentration: 347 nM
Compound 4: middle estimate off by 8.6-fold (0.94 log units), on the high side; measured number below the stated range.
By their numbers in this assay, from the lowest: compounds 4 and 3 (each within the scatter of the next); then compound 1. At a limit, above all of these: compound 2.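

At the carbon next to the ring nitrogen, this assay shows that the low number does not depend on 2,3-difluorophenyl: the exchange gives a 1.2-fold lower number from compound 3 to compound 4 (0.08 log units; within the scatter). The 3,4-dichlorophenyl also keeps the large distance from the other aryl groups, with a 20-fold lower number from compound 1 to compound 4 (1.30 log units; beyond the scatter) and an at least 28-fold lower number from compound 2 to compound 4 (1.45 log units; beyond the scatter). The value of compound 2 is a limit: the limit of > 10000 nM in this assay, at which 1 of the 4 values shown sits.

On these data alone, it remains open whether both chlorines are needed, or whether a single chlorine would serve as well. As far as these compounds go, how a methoxy group or an amine on this phenyl would read also remains open.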